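The compounds below may be only part of what the source reports. "The series", "measured", "known", "first", "only" and "open" are said of these compounds alone.

Measured compounds:
- compound 1, `CCNc1c(NCc2ccc(OC)cc2)ncnc1-c1ccco1`: for compound 1 the entry in an ADME assay on Vero cells (Chlorocebus sabaeus) for cytotoxicity, read by MTT assay, with a stated time of 72 h (on this read-out higher numbers stand for weaker inhibition and lower numbers for stronger inhibition), is "not determined" (no result reported)
- compound 2, `COc1ccc(CNc2ncnc(-c3ccco3)c2[N+](=O)[O-])cc1`: for compound 2 the entry in this assay is "not determined" (no result reported)
- compound 3, `COc1ccc(CNc2ncnc(-c3ccco3)c2NC=O)cc1`: compound 3 gives > 40 ug/mL in this assay

Of the three compounds shown, only compound 3 has any result in this assay, and that result is a limit of the assay rather than a number: the inhibition had not reached half at the highest concentration tested, so the reading for compound 3 is > 40 ug/mL. The other two entries carry no value at all, so compound 3 cannot be placed above or below anything; it simply sits at the limit of > 40 ug/mL in this assay, at which 1 of the 3 values shown sits.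

Compound 4, `COc1ccc(CNc2nc([N+](=O)[O-])nc(-c3ccco3)c2NC=O)cc1`, is the compound still to be tested. It differs from compound 3 in a single place: nitro in place of hydrogen on an aromatic carbon, namely on an aromatic carbon of a six-membered aromatic ring with two nitrogen atoms, between two ring nitrogen atoms, meta to the furan-2-yl group and para to the formylamino group.

Among the compounds with values here, no pair of measured compounds differs in one place, so no measured step gives a scale for this change. With compound 3 already at a limit, the expectation for compound 4 is a step of no clear direction and within the scatter, that is a step that the limit leaves unreadable from compound 3 to compound 4. Compound 4 is therefore estimated to show about 50 ug/mL, between 20 ug/mL and 120 ug/mL, with a real chance that the assay again reports only a limit.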

Compound 4, half-maximal inhibitory concentration: > 40 ug/mL
Compound 4: a limit, no number (the forecaster's own chance of this, stated with the estimate: 65%); the middle value is on the limit's open side.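

In this assay, within the data shown here, compound 3 and compound 4 each give only a limit of the assay, not a number, so no step between them can be read: the limit of > 40 ug/mL in this assay, at which 2 of the 4 values shown sit.

On these data alone, what stays open is whether nitro in place of hydrogen on an aromatic carbon changes the half-maximal inhibitory concentration at all, and in which direction.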